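Amide nitrogen substituents on the shared core: weak activity

A few compounds are considered here, and "the series" means these few. Any claim that something is new, unique, unknown or untested is made for them only; others in the source may bear on it.

Measured compounds and values in an ADME assay on MRC5 cells (Homo sapiens) for inhibition, with a stated time of 72 h; a lower number here means that less compound is needed, a higher number that more compound is needed for the effect:
- compound 1 `COc1cccc(OC)c1C(=O)Nc1c[nH]nc1C(=O)Nc1ccncc1`: > 50000 nM, a limit of the assay
- compound 2 `COc1cccc(OC)c1C(=O)Nc1c[nH]nc1C(=O)NC1CCCCCC1`: 42000 nM
- compound 3 `COc1cccc(OC)c1C(=O)Nc1c[nH]nc1C(=O)NC1CC1`: > 50000 nM, a limit of the assay

Compound 3 stands at the limit of > 50000 nM in this assay, at which 2 of the 3 values shown sit. Compound 1 sits at the same limit, so the pair gives no readable step. Among the measured compounds shown here, compound 2 is the only member with a number, and an at least 1.1-fold higher number from compound 2 to compound 3 (0.07 log units; that floor lies within the scatter) shows how little that number separates it from the limit. Likewise a step that the two limits leave unreadable from compound 1 to compound 3 adds nothing, and an at least 1.1-fold lower number from compound 1 to compound 2 (0.07 log units; that floor lies within the scatter) lies within the scatter.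

The step to compound 4 `COCCNC(=O)c1n[nH]cc1NC(=O)c1c(OC)cccc1OC` is 2-methoxyethyl in place of cyclopropyl on an amide-type nitrogen. The measured steps that bear on it are the two changes on the same amide-type nitrogen, pyridin-4-yl to cyclopropyl and cycloheptyl to cyclopropyl, and neither moves the read-out beyond the scatter or off the limit. Three different groups on that nitrogen have given three essentially indistinguishable results near the top of the measurable range, and a 2-methoxyethyl group gives no basis for expecting otherwise.

The step of a number no higher from compound 3 to compound 4 (the limit leaves the size open) is therefore expected to lie within the scatter, with a substantial chance that only a limit is reported. For compound 4 the estimate is 50000 nM, with a range from 25000 nM to 120000 nM.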

Compound 4, half-maximal effective concentration: > 50000 nM
Compound 4 gave a limit, no number; the forecaster's own chance of this, stated with the estimate: 60%; the middle value sits exactly at the limit.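

In this assay compound 4 gives > 50000 nM, a limit of the assay and not a number. With 2-methoxyethyl, this amide-type nitrogen now carries a substituent with no ring and with an ether oxygen, yet the steps from compound 1 and compound 3 to compound 4 cannot be read, as both ends of each are limits, and an at least 1.1-fold higher number from compound 2 to compound 4 (0.07 log units; that floor lies within the scatter) gives no separation beyond the scatter from the cycloheptyl amide. Ring-bearing and open-chain groups on this nitrogen therefore cannot be told apart in this read-out, and the series remains crowded at the top of the range: the limit of > 50000 nM in this assay, at which 3 of the 4 values shown sit.

From the compounds shown here alone, whether a chain carrying an amine, a carboxylic acid or a longer alkyl chain on this nitrogen would give a value clearly separated from the limit stays open, as does the effect of any change elsewhere on the shared core. Going by these compounds, the true values of compound 1, compound 3 and compound 4 also remain unknown, so any order among them and compound 2 is unresolved.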